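The source may report more compounds than this note shows. Statements on the series, on what has been measured and on what is new or still open speak of the compounds shown alone.

compound 1 `Cc1cc(C)cc(S(=O)(=O)c2c(C(N)=O)[nH]c3ccc(Cl)cc23)c1` – 13000 nM
compound 2 `Cc1cc(C)cc(S(=O)(=O)c2c(C(=O)N[C@@H]3CCN(CC(N)=O)C3)[nH]c3ccc(Cl)cc23)c1` – 31000 nM
compound 3 `Cc1cc(C)cc(S(=O)(=O)c2c(C(=O)N[C@H]3CCN(CC(N)=O)C3)[nH]c3ccc(Cl)cc23)c1` – 28100 nM

All three values come from an ADME assay on MT4 cells (Homo sapiens) for cytotoxicity, read by MTT assay, with a stated time of 5 days; a lower number here means that less compound is tolerated, a higher number that more compound is tolerated. Compound 3 stands level with compound 2, a 1.1-fold lower number from compound 2 to compound 3 (0.04 log units; within the scatter), and clear of compound 1, a 2.2-fold higher number from compound 1 to compound 3 (0.33 log units; beyond the scatter).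

Next in the series is compound 4 `Cc1cc(C)cc(S(=O)(=O)c2c(C(=O)NS(C)(=O)=O)[nH]c3ccc(Cl)cc23)c1`, with methylsulfonyl in place of 1-(carbamoylmethyl)pyrrolidin-3-yl on an amide-type nitrogen. Going by the values given here, two measured steps bear on this change from the opposite side. The group that now leaves gave a 2.4-fold higher number from compound 1 to compound 2 (0.38 log units; beyond the scatter) and a 2.2-fold higher number from compound 1 to compound 3 (0.33 log units; beyond the scatter) when it entered on the same nitrogen, both modest. Loss of the defined stereocentre is expected to count for little, given a 1.1-fold lower number from compound 2 to compound 3 (0.04 log units; within the scatter) and (the fact that compounds 2 and 3 differ only in the configuration as drawn). Among the compounds with values here, no measured compound yet carries methylsulfonyl on that nitrogen, so the guide is the removal alone. Compound 4 is therefore expected to fall back part of the way towards compound 1 in this assay. The expected change is small, a 1.4-fold lower number from compound 3 to compound 4 (0.15 log units; within the scatter), and may not clear the scatter. Compound 4 is estimated at 20000 nM, with an expected range of 8000 nM to 50000 nM.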

Compound 4, half-maximal cytotoxic concentration: 40200 nM
For compound 4 the middle estimate is 2.0-fold (0.30 log units) below the measured one; measured number inside the range.
By their numbers in this assay, from the lowest: compound 1; then compounds 3, 2 and 4 (each within the scatter of the next).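

In this assay, methylsulfonyl and 1-(carbamoylmethyl)pyrrolidin-3-yl on the amide-type nitrogen cannot be told apart, with a 1.4-fold higher number from compound 3 to compound 4 (0.16 log units; within the scatter) and a 1.3-fold higher number from compound 2 to compound 4 (0.11 log units; within the scatter). Against the amide hydrogen the step is a 3.1-fold higher number from compound 1 to compound 4 (0.49 log units; beyond the scatter), so the modest rise seen with the earlier substituent does not depend on keeping its pyrrolidine ring or its carbamoylmethyl. Nor does it depend on a defined stereocentre, which fits the earlier pair: the fact that compounds 2 and 3 differ only in the configuration as drawn.

Going by these compounds, it remains open whether a plain methyl, an acetyl or a phenylsulfonyl on that nitrogen would stay level with compound 4 or return to compound 1. With so few substituents at this position, the compounds shown cannot tell whether almost any group there gives this rise or only these two.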